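The source may report more compounds than this note shows. Statements on the series, on what has been measured and on what is new or still open speak of the compounds shown alone.

Measured so far:
compound 1 `CS(=O)(=O)c1cnc(C(=O)CCc2ccc(-c3ccccc3)cc2)o1`, 1.2 nM
compound 2 `COC(=O)c1cc(-c2cnc(C(=O)CCc3ccc(-c4ccccc4)cc3)o2)ccn1`, 1.5 nM
compound 3 `O=C(O)c1cccc(-c2cnc(C(O)CCc3ccc(-c4ccccc4)cc3)o2)n1`, 1100 nM

In an assay for inhibition of Fatty-acid amide hydrolase 1 (Rattus norvegicus) (on this read-out higher numbers stand for weaker inhibition and lower numbers for stronger inhibition), compound 2 stands second highest of the three numbers, close to compound 1, which gives 1.2 nM, and far from compound 3, which gives 1100 nM. Compound 3 differs from compound 2 in more than one place, so its value is set aside here. Compound 4 `N#Cc1cccc(-c2cnc(C(=O)CCc3ccc(-c4ccccc4)cc3)o2)n1` differs from compound 2 by 6-cyanopyridin-2-yl in place of 2-(methoxycarbonyl)pyridin-4-yl on an aromatic carbon. Among the measured compounds shown here, the one measured step that bears on a change of the group at this position, a 1.3-fold higher number from compound 1 to compound 2 (0.10 log units; within the scatter), lay within the scatter. The step of a 1.3-fold higher number from compound 2 to compound 4 (0.12 log units; within the scatter) is therefore expected to stay small, with no clear direction. Compound 4 is estimated at 2 nM, with a range from 0.5 nM to 8 nM.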

Compound 4, inhibition constant: 2.9 nM
Compound 4: middle estimate off by 1.5-fold (0.16 log units), on the low side; the range from low to high includes it.
By their numbers in this assay, from the lowest: compounds 1, 2 and 4 (each within the scatter of the next, the first and the last beyond it); then compound 3.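

The step of a 1.9-fold higher number from compound 2 to compound 4 (0.29 log units; within the scatter) shows that this position, on the carbon next to the ring oxygen, accepts 6-cyanopyridin-2-yl as readily as 2-(methoxycarbonyl)pyridin-4-yl. Among the compounds shown here, the step of a 2.4-fold higher number from compound 1 to compound 4 (0.38 log units; beyond the scatter) is the first at this position to pass the scatter, and it is modest, so even methylsulfonyl and 6-cyanopyridin-2-yl lie close together. No measurement given here accounts for either step. Still open, on these data alone, is whether an amine or a primary amide in place of the nitrile would keep the number near that of compound 4.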